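The source may report more compounds than this note shows. Statements on the series, on what has been measured and on what is new or still open speak of the compounds shown alone.

Working notes on the series. Compound 1 `CN1CCN(c2nc(N)nc(COc3cccc(Cl)c3)n2)CC1` carries a 3-chlorophenyl on the oxygen of the shared core; in an assay on HEK293 cells for displacement of a labelled ligand from 5-hydroxytryptamine receptor 6 (Homo sapiens), read by radioligand binding, with a stated time of 1 h (on this read-out lower numbers stand for stronger inhibition and higher numbers for weaker inhibition), compound 1 gives 148 nM. Among the compounds with values here, compound 2 `Cc1ccc(C(C)C)c(OCc2nc(N)nc(N3CCN(C)CC3)n2)c1` is the only other measured member; in this assay compound 2 gives 11 nM. Of the two numbers, compound 1 stands at the higher end, and its gap to compound 2 lies beyond the scatter.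

Compound 3 `Cc1ccc(OCc2nc(N)nc(N3CCN(C)CC3)n2)cc1` has not yet been measured. It differs from compound 1 in one place: 4-methylphenyl in place of 3-chlorophenyl on an oxygen on a saturated carbon. The two groups match in everything counted apart from the chlorine against the extra carbon.

Within the data shown here, no measured pair isolates this change, so the expectation can only lean on compound 2, whose more substituted phenyl gives 11 nM, while the 3-chlorophenyl of compound 1 gives 148 nM. Compound 3 is expected to come nearer to compound 2 because compound 2 gives 11 nM. The expected step is a 1.9-fold lower number from compound 1 to compound 3 (0.27 log units; within the scatter), small and possibly within the scatter. For compound 3 the estimate in this assay is 80 nM, with a range from 30 nM to 250 nM.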

Compound 3, inhibition constant: 235 nM
The estimate for compound 3 lay 2.9-fold (0.47 log units) below the measured number, and the stated range covers the measured number.
By their numbers in this assay, from the lowest: compound 2; then compounds 1 and 3 (each within the scatter of the next).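

In this assay, within the data shown here, 4-methylphenyl in place of 3-chlorophenyl on an oxygen on a saturated carbon gives a 1.6-fold higher number from compound 1 to compound 3 (0.20 log units; within the scatter) as the first single-place comparison at this position, so the two groups, which match in everything counted apart from the chlorine against the extra carbon, are not told apart by this read-out. Among these compounds, the more substituted phenyl remains the only group here with a markedly lower number: compound 3 gives 235 nM, while compound 2, which carries an additional isopropyl group on the phenyl, gives 11 nM. Nothing measured here offers an explanation for how closely compound 1 and compound 3 read or for the low number of compound 2.

The compounds shown leave open whether the isopropyl group alone accounts for the number of compound 2, or whether it depends on being paired with the methyl group on the same phenyl. They also leave open how an unsubstituted phenyl, a phenyl carrying an amine or a carboxylic acid, or a longer chain on the same oxygen would read in this assay.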